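From 1,3-thiazol-2-yl to pyridin-2-yl on a shared core

A few compounds are considered here, and "the series" means these few. Any claim that something is new, unique, unknown or untested is made for them only; others in the source may bear on it.

Compound 1 (`Cc1ccncc1-c1cccc2c1cnn2-c1nccs1`) carries a 1,3-thiazol-2-yl group on an aromatic nitrogen of its core. Among the compounds with values here, in an ADME assay on liver (Mus musculus) for metabolic stability, using microsomes, with a stated time of 10 min, tested at 0.5 uM (on this read-out higher numbers stand for a more stable compound and lower numbers for a less stable compound), compound 1 gives 8% and compound 2 (`Cc1ccncc1-c1cccc2c1cnn2-c1ccc(F)cc1`) gives 11% so the only two numbers available lie within the scatter of each other, and both sit close to the bottom of the scale.

Compound 3 (`Cc1ccncc1-c1cccc2c1cnn2-c1ccccn1`) has not yet been measured. It has pyridin-2-yl in place of 1,3-thiazol-2-yl on an aromatic nitrogen. Within the data shown here, one measured step bears on this change, since it replaces the same group at the same place: 4-fluorophenyl in place of 1,3-thiazol-2-yl gives a number 3 percentage points higher from compound 1 to compound 2 (within the scatter) in this series. A single step is thin evidence, but with compound 2 at 11% no shift beyond the scatter is expected in this assay for the new group. The estimated step is a number 2 percentage points higher from compound 1 to compound 3 (within the scatter) and it carries no clear direction. Compound 3 is therefore expected to give about 10% (estimated range 3% to 22%).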

Compound 3, percent of the compound remaining: 8%
The estimate for compound 3 lay 2 percentage points above the measured number; measured number inside the range.
By their numbers in this assay, from the lowest: compounds 1, 3 and 2 (each within the scatter of the next).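

Going to pyridin-2-yl in this assay gives no change at the digits printed from compound 1 to compound 3 (within the scatter), and putting the same group in place of 4-fluorophenyl gives a number 3 percentage points lower from compound 2 to compound 3 (within the scatter). Within the data shown here, three different aromatic rings on this nitrogen, one five-membered with 2 hetero atoms, one six-membered with 1 hetero atom and one fluorine-bearing phenyl, now give numbers within the scatter of each other, all close to the bottom of the scale, whereas the earlier pair could speak for only two groups. What the new step adds is that moving from the thiazole to a six-membered ring with a single ring nitrogen leaves the read-out where it was, and nothing measured here offers an explanation for that flat result.

The compounds shown leave open whether a group of another kind on this nitrogen, such as a morpholine ring or an open chain ending in an amine, would shift the number beyond the scatter. They also leave open how much of the low stability belongs to this position at all, as all three compounds share the same core.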